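A Trifluoromethyl Variant in a Series at the Assay Limit

The source may report more compounds than this note shows. Statements on the series, on what has been measured and on what is new or still open speak of the compounds shown alone.

In a functional assay on HL-60 cells (Homo sapiens) for cytotoxicity, read by MTT assay, with a stated time of 4 days (a lower number here means a stronger inhibitor, a higher number a weaker inhibitor), compound 2 `Cc1ccc(-c2cn(C[C@H]3c4c(ccc(OS(=O)(=O)c5ccc(C)cc5)c4C)[C@@H]4CC[C@@]5(C)C[C@]43CC5=O)nn2)cc1` gives only the assay limit, > 20000 nM. Compound 1 `Cc1ccc(S(=O)(=O)Oc2ccc3c(c2C)[C@H](Cn2cc(-c4ccccc4)nn2)[C@@]24CC(=O)[C@@](C)(CC[C@@H]32)C4)cc1` likewise gives only the limit, > 20000 nM. Between these two sits a step that the two limits leave unreadable from compound 1 to compound 2, and the limit of > 20000 nM in this assay, at which 2 of the 2 values shown sit, is all the two values show. Compound 3 `Cc1ccc(S(=O)(=O)Oc2ccc3c(c2C)[C@H](Cn2cc(-c4ccc(C(F)(F)F)cc4)nn2)[C@@]24CC(=O)[C@@](C)(CC[C@@H]32)C4)cc1` differs from compound 2 by trifluoromethyl in place of methyl on an aromatic carbon. Among the compounds with values here, no measured step bears on this change, and both values so far are limits, so no step beyond the scatter can be read in this assay. Compound 3 is therefore expected to sit at the limit as well, with an estimate of 30000 nM, between 10000 nM and 100000 nM. This estimate means an expected step that the limit leaves unreadable from compound 2 to compound 3.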

Compound 3, half-maximal inhibitory concentration: > 20000 nM
Compound 3: no number, only a limit; the forecaster's own chance of this, stated with the estimate: 85%; the middle value does not contradict the limit.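

In this assay, within the data shown here, compound 3 gives > 20000 nM, a limit of the assay, so no step to it from compound 1 or compound 2 can be read. The compounds shown leave open whether hydrogen, methyl or trifluoromethyl at this place makes any difference to cytotoxicity.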